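A few compounds are considered here, and "the series" means these few. Any claim that something is new, unique, unknown or untested is made for them only; others in the source may bear on it.

Compound 2 `O=C(Nc1nnc(-c2ccc3c(c2)OCCO3)s1)c1ccncc1` is one of two amides built on a shared core. In a functional assay on BGC-823 cells (Homo sapiens) for antiproliferative activity, read by MTT assay, with a stated time of 48 h (a higher number here means that more compound is needed for the effect, a lower number that less compound is needed), compound 2 gives 41 ug/mL. Going by the values given here, its only comparator is compound 1 `O=C(/C=C/c1ccccc1)Nc1nnc(-c2ccc3c(c2)OCCO3)s1`, which in this assay gives 45.4 ug/mL; the step of a 1.1-fold lower number from compound 1 to compound 2 (0.04 log units; within the scatter) leaves the two essentially indistinguishable, so compound 2 cannot be called more or less active than compound 1 on these numbers.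

Compound 3 `Cc1ccc(C(=O)Nc2nnc(-c3ccc4c(c3)OCCO4)s2)cn1` is the next member to be tested. It differs from compound 2 in one place: 6-methylpyridin-3-yl in place of pyridin-4-yl on a carbonyl carbon. Among the compounds with values here, no measured step addresses this particular exchange of one pyridinyl for another. Within the data shown here, the single step in hand, from the 2-phenylethenyl amide to the pyridin-4-yl amide, replaced the whole group on the carbonyl carbon and still produced no change beyond the scatter, which suggests that this position tolerates variation without a large shift in this assay. Compound 3 is therefore expected to show a step of about a 1.0-fold lower number from compound 2 to compound 3 (0.01 log units; within the scatter), that is, nothing beyond the scatter. The estimate for compound 3 is 40 ug/mL, with a range from 18 ug/mL to 90 ug/mL.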

Compound 3, half-maximal effective concentration: > 100 ug/mL
Compound 3 was reported as a limit (the forecaster's own chance of this, stated with the estimate: 10%); middle value at least 2.5-fold (0.39 log units) away from the limit.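

The exchange of pyridin-4-yl for 6-methylpyridin-3-yl on the carbonyl carbon gives, in this assay, an at least 2.4-fold higher number from compound 2 to compound 3 (0.38 log units; beyond the scatter), and so this is the first change at this position shown to lie beyond the scatter. Set against the 2-phenylethenyl amide, the same compound gives an at least 2.2-fold higher number from compound 1 to compound 3 (0.34 log units; beyond the scatter), which shows that the earlier step, small as it was between two quite different groups, did not mean that this position accepts any group in this assay; two pyridine-bearing amides, with the same count of hetero atoms, donors and acceptors in the group, can differ more than a pyridine-bearing amide and a 2-phenylethenyl amide do. The number for compound 3 is a limit and not a measured value: the limit of > 100 ug/mL in this assay, at which 1 of the 3 values shown sits.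

The compounds shown leave open whether the added methyl or the change from a pyridin-4-yl to a pyridin-3-yl group lies behind the step, a question that the unsubstituted pyridin-3-yl amide would address. Going by these compounds, how the assay responds to other groups on this ring, such as an amine or a carboxylic acid, also remains open.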